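The compounds below may be only part of what the source reports. "The series", "measured", "known", "first", "only" and "open" are said of these compounds alone.

Working notes on the series. Among the compounds with values here, in an ADME assay for permeability, using PAMPA (a higher number here means that the compound crosses the layer faster, a lower number that the compound crosses the layer more slowly), compound 1 (`Cc1ccc(O)c(C(=O)Nc2ccc([N+](=O)[O-])cc2Cl)c1`) gives 134 10^-6 cm/s and compound 2 (`O=C(Nc1ccc([N+](=O)[O-])cc1Cl)c1cc([N+](=O)[O-])ccc1O`) gives 30.3 10^-6 cm/s, so compound 2 holds the lower of the two numbers so far, with the gap beyond the scatter. Next is compound 3 (`CC(=O)c1ccc(O)c(C(=O)Nc2ccc([N+](=O)[O-])cc2Cl)c1`), which has acetyl in place of nitro on an aromatic carbon, para to a hydroxy group: acetyl in place of nitro on an aromatic carbon. Within the data shown here, one measured step bears on this change, a 4.4-fold lower number from compound 1 to compound 2 (0.65 log units; beyond the scatter), a modest step with nitro in place of methyl on the same aromatic carbon. Acetyl is absent from both measured compounds, so that step gives only a rough guide. A smaller step towards a higher number in this assay is expected. The estimated step is a 2.0-fold higher number from compound 2 to compound 3 (0.30 log units; within the scatter). For compound 3 the expected value is 60 10^-6 cm/s, with an estimated range of 25 10^-6 cm/s to 140 10^-6 cm/s.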

Compound 3, apparent permeability in the ADME assay: 33.1 10^-6 cm/s
Compound 3: middle estimate off by 1.8-fold (0.26 log units), on the high side; low and high end bracket the measured number.
By their numbers in the ADME assay, from the lowest: compounds 2 and 3 (each within the scatter of the next); then compound 1.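

In the ADME assay there is a 1.1-fold higher number from compound 2 to compound 3 (0.04 log units; within the scatter), so acetyl and nitro, at this position para to a hydroxy group, cannot be told apart here even though acetyl carries carbon where nitro carries nitrogen, and acetyl has 1 hydrogen-bond acceptor where nitro has 2 hydrogen-bond acceptors. Methyl does stand apart from acetyl, with a 4.0-fold lower number from compound 1 to compound 3 (0.61 log units; beyond the scatter), so compound 1 is now separated beyond the scatter from both other compounds. In a physicochemical assay for solubility (a lower number here means a less soluble compound, a higher number a more soluble compound), compound 2 gives > 50 ug/mL, which is a limit of the assay. In the physicochemical assay compound 3 gives > 49 ug/mL, which is also a limit of the assay. The step between these two compounds cannot be read, and no measurement shown accounts for the permeability numbers.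

Going by these compounds, whether an amine or a carboxylic acid at this position would fall with acetyl and nitro or with methyl remains open. A longer chain here is equally untested by the compounds shown.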